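The compounds below may be only part of what the source reports. "The series", "measured", "known", "first", "only" and "open" are said of these compounds alone.

Compound 1 (`COc1ccc(NC(=O)Nc2ccc(Nc3ncnc4c3OCCN4)cc2)cc1`) reaches only a limit in a functional assay on BaF3 cells (Mus musculus) for inhibition, read by MTT assay, with a stated time of 3 days (a higher number here means a weaker inhibitor of growth, a lower number a stronger inhibitor of growth), at > 10000 nM. Compound 2 (`Cc1ccc(F)c(NC(=O)Nc2ccc(Nc3ncnc4c3OCCN4)cc2)c1`) also gives only a limit, at > 10000 nM. Going by the values given here, compound 3 (`CC(C)(C)c1cc(NC(=O)Nc2ccc(Nc3ncnc4c3OCCN4)c(F)c2)no1`) gives 10000 nM, the only actual number among the three, and it stands close to the limit of > 10000 nM in this assay, at which 2 of the 3 values shown sit.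

The next compound, compound 4 (`CC(C)(C)c1cc(NC(=O)Nc2ccc(Nc3ncnc4c3OCCN4)c(O)c2)no1`), carries hydroxy in place of fluoro on an aromatic carbon, ortho to a large group and meta to a large group: hydroxy in place of fluoro on an aromatic carbon.

Among the compounds with values here, only one measured step is available, a step that the two limits leave unreadable from compound 1 to compound 2. It cannot be sized and concerns a different group, so it gives no guide to this change. With nothing to suggest a gain, compound 4 is expected to remain weak in this assay, close to compound 3 at 10000 nM. The expected change is no change at the digits printed from compound 3 to compound 4 (within the scatter), with no firm direction, and a reading at the limit is quite possible. For compound 4 the estimate is 10000 nM, with an expected range of 4000 nM to 20000 nM.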

Compound 4, concentration for 50% growth inhibition: > 10000 nM
Compound 4 gave a limit, no number; the forecaster's own chance of this, stated with the estimate: 55%; the middle value sits exactly at the limit.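

In this assay compound 4 gives > 10000 nM as a limit and not a number. Hydroxy in place of fluoro on this aromatic carbon, ortho to a large group and meta to a large group, therefore brings no readable gain, with a number no lower from compound 3 to compound 4 (the limit leaves the size open) as the only reading, and the size of that step cannot be read. The earlier compounds shown here offered no step at this position, and this one shows that the change leaves the series at the edge of the readable range: the limit of > 10000 nM in this assay, at which 3 of the 4 values shown sit.

The compounds shown leave open how far compound 4 really lies from compound 3. They also leave open whether another group on this carbon, such as an amine or a carboxylic acid, would give an actual number in this assay at all.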